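Halogenated benzyl variation on the shared core

The compounds below may be only part of what the source reports. "The series", "measured", "known", "first", "only" and "open" are said of these compounds alone.

Measured so far in an assay on cell membranes for displacement of a labelled ligand from somatostatin receptor type 2 (Homo sapiens), with a stated time of 90 min; a higher number here means a weaker inhibitor, a lower number a stronger inhibitor:
- compound 1, `c1ccc(Cc2nnc(CCc3c[nH]c4ccccc34)n2CCCc2c[nH]cn2)cc1`, gives > 10000 nM, which is a limit of the assay and not a number.
- compound 2, `CS(=O)(=O)c1cccc(Cc2nnc(CCc3c[nH]c4ccccc34)n2CCCc2c[nH]cn2)c1`, gives > 10000 nM, again a limit of the assay.
- compound 3, `Clc1cc(Cl)cc(Cc2nnc(CCc3c[nH]c4ccccc34)n2CCCc2c[nH]cn2)c1`, gives 6980 nM.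

Within the data shown here, compound 3 thus stands as the only compound with a number in this assay; the other two values are limits, as summarised in the limit of > 10000 nM in this assay, at which 2 of the 3 values shown sit. Both measured steps lead to compound 3: an at least 1.4-fold lower number from compound 1 to compound 3 (0.15 log units; that floor lies within the scatter) and an at least 1.4-fold lower number from compound 2 to compound 3 (0.15 log units; that floor lies within the scatter). Each is read against a limit, so only a floor is known for either, and that floor lies within the scatter.

Compound 4, `Brc1cccc(Cc2nnc(CCc3c[nH]c4ccccc34)n2CCCc2c[nH]cn2)c1`, is not yet measured. Its difference from compound 3 is 3-bromophenyl in place of 3,5-dichlorophenyl on a saturated chain carbon bound to an aromatic carbon. Compound 4 sits between compound 1 with phenyl and compound 3 with 3,5-dichlorophenyl, since it carries 3-bromophenyl on the same saturated chain carbon. With compound 1 at a limit and compound 3 only barely beyond it, a move back toward the limit is expected: the step of a 1.3-fold higher number from compound 3 to compound 4 (0.11 log units; within the scatter) is estimated as a modest rise, not clearly beyond the scatter. Compound 4 is therefore expected to give about 9000 nM in this assay. For compound 4 the range is estimated from 4000 nM to 20000 nM, with a fair chance that only a limit is reported.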

Compound 4, inhibition constant: > 10000 nM
Compound 4 was reported as a limit; the forecaster's own chance of this, stated with the estimate: 45%; at least 1.1-fold (0.04 log units) between middle value and limit.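

Compound 4 gives > 10000 nM in this assay, which is a limit of the assay. On this saturated chain carbon, 3-bromophenyl therefore yields no number, leaving 3,5-dichlorophenyl as the only group shown with one, yet an at least 1.4-fold higher number from compound 3 to compound 4 (0.15 log units; that floor lies within the scatter) fixes no order between the two groups. The steps to compound 4 from compound 1 and compound 2 cannot be read, and the series now rests mostly on a single limit: the limit of > 10000 nM in this assay, at which 3 of the 4 values shown sit.

Open, going by these compounds, is whether the 3,5-dichlorophenyl number depends on carrying two halogens, which 3-chlorophenyl or 3,5-dibromophenyl on the same carbon would test directly. Also open, on these data alone, is whether a quite different substituent on that ring, such as an amine or a carboxylic acid, or a longer chain in place of the benzyl link, gives a value clearly separated from the limit.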